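The compounds below may be only part of what the source reports. "The series", "measured", "known", "first", "only" and "open" are said of these compounds alone.

Compound 1 `COc1ccccc1/C=C/C(=O)/C=C/c1ccc(OCc2cn(CCOc3cc(=O)oc4ccccc34)nn2)c(OC)c1` is one of three dienone-triazole compounds measured in a functional assay on THP-1 cells (Homo sapiens) for inhibition, read by sulforhodamine B assay, with a stated time of 48 h, tested at 50 uM; on this read-out higher numbers stand for more inhibition of growth at the one concentration tested and lower numbers for less inhibition of growth. In this assay compound 1 gives 75%, the highest of the three numbers. Compound 3 `COc1cc(/C=C/C(=O)/C=C/c2cccc3ccccc23)ccc1OCc1cn(CCCOc2cc(=O)oc3ccccc23)nn1` gives 71% in this assay, which lies within the scatter of the value for compound 1. Compound 2 `COc1cc(/C=C/C(=O)/C=C/c2ccccc2)ccc1OCc1cn(CCCCCOc2cc(=O)oc3ccccc23)nn1` gives 26% in this assay, a number far below that of compound 1 and beyond the scatter. Among the compounds with values here, no pair of these three differs in a single place, so no single-change step can be drawn from them.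

Compound 4 `COc1cccc(/C=C/C(=O)/C=C/c2ccc(OCc3cn(CCOc4cc(=O)oc5ccccc45)nn3)c(OC)c2)c1` has not yet been measured. It differs from compound 1 in one place, as follows: 3-methoxyphenyl in place of 2-methoxyphenyl on a double-bonded chain carbon bound to a double-bonded chain carbon. Because compound 1 gives 75% and the change keeps the same atoms, moving only the methoxy group on that phenyl ring, the step is expected to fall within the scatter, with no clear direction, and the expected step is a number 5 percentage points lower from compound 1 to compound 4 (within the scatter). Compound 4 is therefore expected to give about 70% in this assay, estimated between 50% and 85%.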

Compound 4, percent growth inhibition at one concentration: 77%
Estimate against measurement, compound 4: 7 percentage points below; the range from low to high includes it.
By their numbers in this assay, from the lowest: compound 2; then compounds 3, 1 and 4 (each within the scatter of the next).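

In this assay, within the data shown here, replacing 2-methoxyphenyl with 3-methoxyphenyl gives a step of a number 2 percentage points higher from compound 1 to compound 4 (within the scatter) and is the first single-place change in this set, which the earlier compounds could not provide. It shows that, on a double-bonded chain carbon bound to a double-bonded chain carbon, these two methoxyphenyl groups are not told apart by this read-out at the one concentration tested. Nothing available here accounts for this result.

The compounds shown leave open whether a phenyl ring carrying an amine or a carboxylic acid in place of the methoxy group would also stay within the scatter at this place. They also leave open whether the same change would behave alike on a compound with a longer chain.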